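Fluoro for bromo on the 2-bromophenyl of compound 3

The source may hold more compounds than are shown below. What is called first, only, known or untested is meant among the compounds shown, and "the series" means these compounds.

Compound 1 `O=[N+]([O-])c1ccc(CN2CCC(n3cc(CC(OCc4cc(-c5cccc(Br)c5)no4)c4ccc(Br)cc4)nn3)CC2)cc1` gives 3000 nM in a functional assay on Huh-7 cells (Homo sapiens) for cytotoxicity, with a stated time of 48 h; on this read-out higher numbers stand for weaker inhibition and lower numbers for stronger inhibition. Compound 2 `O=[N+]([O-])c1ccc(CN2CCC(n3cc(CC(OCc4cc(-c5cccc(F)c5)no4)c4ccc(Br)cc4)nn3)CC2)cc1` carries the change fluoro in place of bromo on an aromatic carbon and in this assay compound 2 gives 3000 nM, so that no change at the digits printed from compound 1 to compound 2 (within the scatter). Compound 3 `O=[N+]([O-])c1ccc(CN2CCC(n3cc(CC(OCc4cc(-c5ccccc5Br)no4)c4ccc(Br)cc4)nn3)CC2)cc1` differs from compound 1 by 2-bromophenyl in place of 3-bromophenyl on an aromatic carbon. For compound 3 this assay reports only a limit, not a number: compound 3 gives > 25000 nM (the limit of > 25000 nM in this assay, at which 1 of the 3 values shown sits). Against the two measured analogues, an at least 8.3-fold higher number from compound 1 to compound 3 (0.92 log units; beyond the scatter) and an at least 8.3-fold higher number from compound 2 to compound 3 (0.92 log units; beyond the scatter). Compound 4 `O=[N+]([O-])c1ccc(CN2CCC(n3cc(CC(OCc4cc(-c5ccccc5F)no4)c4ccc(Br)cc4)nn3)CC2)cc1` is not yet measured; it differs from compound 3 by fluoro in place of bromo on an aromatic carbon. This is the same kind of change as from compound 1 to compound 2, but not the same: there the halogen sits meta to a large group, here ortho to a large group. The step from compound 3 to compound 4 is expected to be a number no higher from compound 3 to compound 4 (the limit leaves the size open), resting on no change at the digits printed from compound 1 to compound 2 (within the scatter) and on the starting point of compound 3 being a limit. Compound 4 is therefore estimated at 25000 nM, with a likely range from 8000 nM to 70000 nM, and a limit rather than a number is the more probable read-out.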

Compound 4, half-maximal inhibitory concentration: 2000 nM
Compound 4: middle estimate off by 13-fold (1.10 log units), on the high side; the whole stated range lies above it.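

On the core of compound 3, with the halogen ortho to a large group, fluoro in place of bromo gives an at least 12-fold lower number from compound 3 to compound 4 (1.09 log units; beyond the scatter) in this assay, and this step does not match the one on the core of compound 1: the same change on two cores in this assay, no change at the digits printed (within the scatter) from compound 1 to compound 2 and an at least 12-fold lower number (1.09 log units; beyond the scatter) from compound 3 to compound 4, at least 12-fold (1.09 log units) apart, beyond the scatter of two such steps

Going by these compounds, compound 3 is reported only as a limit, > 25000 nM, so the full size of its step to compound 4 stays open.

The 2-fluorophenyl group reads alike with the 3-fluorophenyl and 3-bromophenyl groups, with a 1.5-fold lower number from compound 2 to compound 4 (0.18 log units; within the scatter) and a 1.5-fold lower number from compound 1 to compound 4 (0.18 log units; within the scatter), which leaves compound 3 alone apart from the others, but four compounds do not show how fluoro in place of bromo would behave on any further core.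

Open, on these data alone, is how 2-chlorophenyl, 2-methylphenyl or 2-methoxyphenyl would read in this assay, which would tell whether 2-bromophenyl is a single exception. Also open, as far as these compounds go, is whether these readings hold with an amine or a carboxylic acid in place of the nitro group.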